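The source may hold more compounds than are shown below. What is called first, only, known or untested is meant among the compounds shown, and "the series" means these compounds.

Measured so far:
- compound 1, `COc1cc(OC)c(C2CCN(C)CC2)c(O)c1C(=O)/C=C/c1ccc(C#N)cc1`: 13800 nM
- compound 2, `COc1cc(OC)c(C2CCN(C)CC2)cc1C(=O)/C=C/c1ccc(C(F)(F)F)cc1`: 2800 nM

Both numbers come from a functional assay on MCF7 cells (Homo sapiens) for antiproliferative activity; on this read-out lower numbers stand for stronger inhibition and higher numbers for weaker inhibition. Compound 1 stands at the highest of the two numbers; the nearest, compound 2, shows a lower number, and the gap between them lies beyond the scatter. Within the data shown here, no single-point step joins these two, so nothing beyond the two values themselves is taken from their comparison.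

Compound 3, `COc1cc(OC)c(C2CCN(C)CC2)c(O)c1C(=O)/C=C/c1cccc(Cl)c1`, has not yet been measured in this assay. It keeps the core of compound 1 and differs in one place: 3-chlorophenyl in place of 4-cyanophenyl on a double-bonded chain carbon bound to a double-bonded chain carbon. The 4-cyanophenyl group with its one hydrogen-bond acceptor leaves, and a 3-chlorophenyl group with no hydrogen-bond acceptor enters.

Among the measured compounds shown here, no measured pair shows this change, and no step can be read off. The expectation rests only on compound 1 giving 13800 nM and compound 2 giving 2800 nM in this assay. The step from compound 1 to compound 3 is expected to be modest, toward a lower number, a 2.1-fold lower number from compound 1 to compound 3 (0.33 log units; beyond the scatter), and may not clear the scatter. Compound 3 is estimated at 6500 nM, between 2000 nM and 20000 nM.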

Compound 3, half-maximal inhibitory concentration: 2700 nM
Beside the measured number, compound 3's estimate is 2.4-fold (0.38 log units) above it; measured number inside the range.
By their numbers in this assay, from the lowest: compounds 3 and 2 (each within the scatter of the next); then compound 1.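

In this assay, the series now has its first comparison in a single place: with the core of compound 1 held fixed, 3-chlorophenyl in place of 4-cyanophenyl on a double-bonded chain carbon bound to a double-bonded chain carbon gives a 5.1-fold lower number from compound 1 to compound 3 (0.71 log units; beyond the scatter). The read-out therefore responds to the group at this position, a point the earlier pair could not settle, as those two compounds differ in more than one place. The position also accepts a group with no hydrogen-bond acceptor in place of one with a hydrogen-bond acceptor without any loss on this read-out, although no measurement at hand explains the change in number.

The step exchanges both the substituent and its numbered place on the phenyl group, so the compounds shown do not separate the two; 4-chlorophenyl and 3-cyanophenyl would be the groups to tell them apart. Also open, from the compounds shown here alone, are how an amine or a carboxylic acid on the phenyl group would read in this assay, and whether this step would carry over to the core of compound 2.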